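Cyclohexyl for tert-butylphenyl on the amide nitrogen

This account rests on a few compounds, and the source may have more. Where it says the series, first, only, none or still open, it means among the compounds named here.

Of the compounds shown here, three sharing one core have been measured in an assay for inhibition of histone-lysine N-methyltransferase, H3 lysine-79 specific (Homo sapiens), read by luminescence, with a stated time of 1 h; on this read-out lower numbers stand for stronger inhibition and higher numbers for weaker inhibition. Compound 1 `Cc1ccc(NC(=O)c2ncn(CC(=O)NCc3ccc4[nH]ncc4c3)n2)cc1C` gives 36900 nM, compound 2 `CC(C)(C)c1ccc(NC(=O)c2ncn(CC(=O)NCc3ccc4[nH]ncc4c3)n2)cc1` gives 22400 nM, and compound 3 `CC(C)(C)c1ccc(NC(=O)c2ncn(CC(=O)NCCn3ccc4c(N)ncnc43)n2)cc1` gives 1000 nM. Compound 2 therefore stands second highest of the three numbers; its nearest neighbour is compound 1 and its furthest is compound 3. The step of a 1.6-fold lower number from compound 1 to compound 2 (0.22 log units; within the scatter) shows that exchanging 3,4-dimethylphenyl for 4-(tert-butyl)phenyl on the amide-type nitrogen left the number within the scatter, whereas a 22-fold lower number from compound 2 to compound 3 (1.35 log units; beyond the scatter) shows that the one large movement came from a change elsewhere on the core.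

Compound 4 `O=C(Cn1cnc(C(=O)NC2CCCCC2)n1)NCc1ccc2[nH]ncc2c1` carries cyclohexyl in place of 4-(tert-butyl)phenyl on an amide-type nitrogen. Going by the values given here, only the step from compound 1 to compound 2 concerns this same nitrogen, and it stayed within the scatter. Among the compounds with values here, no measured compound tells how a non-aromatic ring at this position behaves in this assay, so the expectation rests on that single small step alone. Compound 4 is accordingly expected to give a number close to that of compound 2. The step of a 1.3-fold higher number from compound 2 to compound 4 (0.13 log units; within the scatter) is expected to fall within the scatter. The estimate for compound 4 in this assay is 30000 nM, with a range from 10000 nM to 90000 nM.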

Compound 4, half-maximal inhibitory concentration: > 100000 nM
Compound 4 gave a limit, no number; the forecaster's own chance of this, stated with the estimate: 15%; middle value at least 3.3-fold (0.52 log units) from the limit.
By their numbers in this assay, from the lowest: compound 3; then compounds 2 and 1 (each within the scatter of the next). At a limit, above all of these: compound 4.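

Compound 4 reads only as a limit and not as a number in this assay: the limit of > 100000 nM in this assay, at which 1 of the 4 values shown sits. The amide-type nitrogen, whose one earlier change stayed within the scatter, now proves sensitive to what it carries: cyclohexyl in place of 4-(tert-butyl)phenyl gives an at least 4.4-fold higher number from compound 2 to compound 4 (0.64 log units; beyond the scatter), and cyclohexyl in place of 3,4-dimethylphenyl gives an at least 2.7-fold higher number from compound 1 to compound 4 (0.43 log units; beyond the scatter). The position therefore accepts the exchange of one substituted phenyl group for the other but not the move to this non-aromatic ring, although the change from 4-(tert-butyl)phenyl to cyclohexyl alters both ring type and heavy-atom count, so these two differences cannot be separated here.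

From the compounds shown here alone, whether the aromatic ring or the larger group matters remains open, and a 4-(tert-butyl)cyclohexyl group or an unsubstituted phenyl on this nitrogen would address that question. Going by these compounds alone, also open is whether cyclohexyl would behave the same way alongside the other side chain on the shared core, the one that compound 3 carries.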